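The compounds below may be only part of what the source reports. "The series", "measured", "known", "first", "only" and "open" are said of these compounds alone.

Compound 1 `Cc1cc(NC(=O)Cn2nnc(-c3ccccc3)n2)n(C2CCCCC2)n1`: 92%
Compound 2 `Cc1cc(NC(=O)Cn2nnc(-c3ccccc3)n2)n(C2CCOCC2)n1`: 115%
Compound 3 `Cc1cc(NC(=O)Cn2nnc(-c3ccccc3)n2)n(C2CCS(=O)(=O)CC2)n1`: > 25%, which is a limit of the assay and not a number

The three measured compounds share one core and differ only in the group on an aromatic nitrogen. In an assay on HEK293 cells for activation of Kir3.1/Kir3.2 (Homo sapiens), read by thallium flux (on this read-out lower numbers stand for smaller maximal responses and higher numbers for larger maximal responses), compound 1 stands lowest of the two full numbers; its nearest neighbour is compound 2, reached by a number 23 percentage points higher from compound 1 to compound 2 (beyond the scatter), with oxan-4-yl in place of cyclohexyl. For compound 3 only a limit is known (the limit of > 25% in this assay, at which 1 of the 3 values shown sits). Hence a step that the limit leaves unreadable from compound 1 to compound 3 and a step that the limit leaves unreadable from compound 2 to compound 3 cannot be sized.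

Compound 4 `O=C(Cn1nnc(-c2ccccc2)n1)Nc1cc(C2(C(F)(F)F)CC2)nn1C1CCCCC1` keeps the cyclohexyl of compound 1 and changes a different place: 1-(trifluoromethyl)cyclopropyl in place of methyl on an aromatic carbon. Within the data shown here, none of the measured steps touches this aromatic carbon; all of them concern the group on the aromatic nitrogen, so no measured step bears directly on this change, and there is no ground to expect a step beyond the scatter in either direction, though the uncertainty is wide. Compound 4 is therefore expected at 88%. The estimated range for compound 4 runs from 55% to 115%. This estimate implies an expected a number 4 percentage points lower from compound 1 to compound 4 (within the scatter), within the scatter.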

Compound 4, largest response reached (Emax), in percent of the reference or control that the assay uses: "not active" (no number reported)
Compound 4 has no reported number here; no gap can be computed for the estimate.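

Among these compounds, compound 4 is reported as "not active", with no number, so no step from compound 1 to compound 4 can be read. Nothing shown accounts for this result. The compounds shown leave open how 1-(trifluoromethyl)cyclopropyl in place of methyl would act alongside oxan-4-yl on the aromatic nitrogen.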